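The source may report more compounds than this note shows. Statements on the series, on what has been measured and on what is new or still open speak of the compounds shown alone.

Measured so far in a functional assay on KB cells (Homo sapiens) for inhibition, with a stated time of 72 h; a higher number here means a weaker inhibitor, a lower number a stronger inhibitor:
compound 1, `CC(=O)Oc1c(O)cc2oc(-c3ccccc3)cc(=O)c2c1O`: 10500 nM
compound 2, `CC(=O)Oc1cc2oc(-c3ccccc3)cc(=O)c2c(O)c1OC(C)=O`: 12700 nM

Among the measured compounds shown here, of the two numbers the one for compound 2 is the higher, but its only neighbour is compound 1 and the gap between them falls within the scatter, so the two compounds are not distinguished in this assay. Compound 3, `CC(=O)Oc1cc2oc(-c3ccccc3)cc(=O)c2c(OC(C)=O)c1OC(C)=O`, has not yet been measured in this assay. It differs from compound 2 in one place: acetyl in place of hydrogen on an oxygen on an aromatic ring. For the measured compounds named here, one measured step bears on this change and is of the same kind, acetyl in place of hydrogen on an oxygen on an aromatic ring: a 1.2-fold higher number from compound 1 to compound 2 (0.08 log units; within the scatter). That step did not move the number beyond the scatter. With nothing else in the series to lean on, the expectation for compound 3 in this assay is a step of the same size, a 1.1-fold higher number from compound 2 to compound 3 (0.04 log units; within the scatter), that is, none beyond the scatter. Compound 3 is accordingly estimated at 14000 nM in this assay, with a range from 6000 nM to 35000 nM.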

Compound 3, half-maximal inhibitory concentration: 14500 nM
Beside the measured number, compound 3's estimate is 1.0-fold (0.02 log units) below it; measured number inside the range.
By their numbers in this assay, from the lowest: compounds 1, 2 and 3 (each within the scatter of the next).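

Replacing hydroxy with acetoxy at this further oxygen on an aromatic ring gives in this assay a 1.1-fold higher number from compound 2 to compound 3 (0.06 log units; within the scatter) and so leaves the pair undistinguished. The earlier replacement, a 1.2-fold higher number from compound 1 to compound 2 (0.08 log units; within the scatter) in this assay as well, had shown this outcome at one oxygen only; the same change at two different oxygens now reads alike, and this holds for these two steps and no further. No measured evidence is available to explain why the number stays within the scatter at this position.

As far as these compounds go, both steps exchange hydrogen for acetyl, so it remains open whether this oxygen would read the same with a different group on it, such as a methyl ether, a longer acyl chain like butanoyl, or an acyl chain carrying an amine. From the compounds shown here alone, it also remains open whether a group placed elsewhere on the shared core, such as a carboxylic acid or an amine, would move the number in this assay beyond the scatter when the oxygens carry hydroxy or acetoxy.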